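Trimming a methyl from the side chain of compound 3

A few compounds are considered here, and "the series" means these few. Any claim that something is new, unique, unknown or untested is made for them only; others in the source may bear on it.

Measured so far in a functional assay on the whole organism (Tail, strain ICR) with Mus musculus as the target, in the tail flick test, with a stated time of 90 min, at a dose of 25 umol/kg by the oral route; a higher number here means a stronger effect of the compound at the dose given, a lower number a weaker effect:
compound 1 `N=C(N)NCCC[C@H](NC(=O)CN(c1nc(Cl)nc2[nH]cnc12)C1CC1)C(=O)O` gives 27.6%;
compound 2 `O=C(CN(c1nc(Cl)nc2[nH]cnc12)C1CC1)N[C@@H](CO)C(=O)O` gives 43.9%;
compound 3 `CC[C@H](C)[C@H](NC(=O)CN(c1ncnc2c1ncn2C1CCCCO1)C1CC1)C(=O)OCc1ccccc1` gives 22.6%.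

Compound 3 has the lowest of the three numbers, but its gap to compound 1 lies within the usual scatter; only the gap to compound 2 is beyond it. Compound 4 `CC(C)[C@H](NC(=O)CN(c1ncnc2c1ncn2C1CCCCO1)C1CC1)C(=O)OCc1ccccc1` differs from compound 3 by hydrogen in place of methyl on a saturated chain carbon, three bonds along the chain from an amide-type nitrogen and a carbonyl carbon. Going by the values given here, the one measured step, a number 16.3 percentage points higher from compound 1 to compound 2 (beyond the scatter), concerns a different group at a different place, so it says little about removing a methyl here. Nothing measured bears directly on this change, so no step beyond the scatter is expected: a number 1.4 percentage points higher from compound 3 to compound 4 (within the scatter). Compound 4 is therefore estimated at 24%, between 10% and 40%.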

Compound 4, a percentage reported as activity, at one dose (the size of the read-out at that dose, not a potency): 30.1%
Compound 4: middle estimate off by 6.1 percentage points, on the low side; measured number inside the range.
By their numbers in this assay, from the lowest: compounds 3, 1 and 4 (each within the scatter of the next); then compound 2.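

In this assay the change from sec-butyl to isopropyl gives a number 7.5 percentage points higher from compound 3 to compound 4 (within the scatter) and so, at this place on the side chain, losing one methyl produces no clear shift. Going by these compounds alone, this is the first reading on a side chain of this kind that carries no other change. Nothing available explains the result. The compounds shown leave open whether a plain methyl, a longer chain or an amine at this place would move the number beyond the scatter.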